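Nitro to amino on the dichloro series

This account rests on a few compounds, and the source may have more. Where it says the series, first, only, none or still open, it means among the compounds named here.

Measured so far in an ADME assay on MDBK cells (Bos taurus) for cytotoxicity, read by MTT assay, with a stated time of 96 h; a lower number here means that less compound is tolerated, a higher number that more compound is tolerated 
compound 1 `Oc1ccc(-c2nc3cc(C(F)(F)F)ccc3[nH]2)cc1` gives 51000 nM 
compound 2 `COc1ccc(-c2nc3cc(C(C)=O)ccc3[nH]2)c(OC)c1` gives > 100000 nM as a limit 
compound 3 `O=[N+]([O-])c1ccc(-c2nc3cc(Cl)c(Cl)cc3[nH]2)cc1` gives 56000 nM 

Among the compounds with values here, compound 1 at 51000 nM and compound 3 at 56000 nM lie within the usual scatter of each other, and they are the only two true numbers in the set. Compound 2 stands at > 100000 nM, which is a limit of the assay and not a number.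

Compound 4 `Nc1ccc(-c2nc3cc(Cl)c(Cl)cc3[nH]2)cc1` has amino in place of nitro on an aromatic carbon, para to a large group amino in place of nitro on an aromatic carbon and is otherwise the same as compound 3. Within the data shown here, no two measured compounds differ in one place, so no measured step sizes this change. The estimate therefore starts from compound 3 at 56000 nM and has a wide range. A modest move toward less compound tolerated is expected, a 1.6-fold lower number from compound 3 to compound 4 (0.20 log units; within the scatter), and it may not exceed the scatter. Compound 4 is estimated at 35000 nM in this assay, with 10000 nM to 100000 nM as the expected range.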

Compound 4, half-maximal cytotoxic concentration: 7500 nM
Beside the measured number, compound 4's estimate is 4.7-fold (0.67 log units) above it, and the stated range ends above it.
By their numbers in this assay, from the lowest: compound 4; then compounds 1 and 3 (each within the scatter of the next). At a limit, above all of these: compound 2.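

In this assay, amino in place of nitro on an aromatic carbon, para to a large group, gives a 7.5-fold lower number from compound 3 to compound 4 (0.87 log units; beyond the scatter), so the group at this position on the dichloro series can move the number by more than the scatter. Within the data shown here, until this pair, no single change in the set could be sized, and this one is the first step available for the series. None of the information at hand gives a cause for this step.

A single pair cannot separate the loss of nitro from the arrival of amino, and it cannot tell whether the same step would appear on another core. A carboxylic acid or an acetamide on the same aromatic carbon would help to separate these two readings.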